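The source may hold more compounds than are shown below. What is called first, only, known or untested is meant among the compounds shown, and "the series" means these compounds.

Measured compounds and their values in an ADME assay on MT4 cells (Homo sapiens) for cytotoxicity, read by MTT assay, with a stated time of 4 days; on this read-out lower numbers stand for higher toxicity in this test and higher numbers for lower toxicity in this test:
- compound 1, `Cc1cccc(C)c1Oc1nc(Nc2ccc(C#N)cc2)nc2ccccc12`: 35000 nM
- compound 2, `Cc1cc(C#N)cc(C)c1Oc1nc(Nc2ccc(C#N)cc2)nc2ccc(Cl)cc12`: 117000 nM
- compound 3, `CCOc1cc(C#N)cc(Cl)c1Oc1nc(Nc2ccc(C#N)cc2)nc2ccccc12`: 22000 nM

Among these three numbers compound 1 stands second highest. Its nearest neighbour is compound 3, which gives a number that lies within the scatter of that of compound 1, so no order between the two can be claimed. Compound 2 gives a number that lies beyond the scatter above that of compound 1, so compound 2 shows lower toxicity than compound 1 in this assay.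

The unmeasured compound is compound 4, `Cc1cccc(Oc2nc(Nc3ccc(C#N)cc3)nc3ccccc23)c1`. Compared with compound 1 its change is 3-methylphenyl in place of 2,6-dimethylphenyl on an oxygen on an aromatic ring. Because compound 1 gives 35000 nM and compound 3, with a different group on the same oxygen, gives a number within the scatter of it, the change from compound 1 to compound 4 is expected to make little difference, a 1.2-fold lower number from compound 1 to compound 4 (0.07 log units; within the scatter), a step of no size beyond the scatter. Compound 4 is therefore estimated at 30000 nM, with a range from 12000 nM to 80000 nM.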

Compound 4, half-maximal cytotoxic concentration: 355000 nM
Compound 4: middle estimate off by 12-fold (1.07 log units), on the low side, outside the stated range (above it).
By their numbers in this assay, from the lowest: compounds 3 and 1 (each within the scatter of the next); then compound 2; then compound 4.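

In this assay, the group on this oxygen proves able to shift the read-out strongly: 3-methylphenyl in place of 2,6-dimethylphenyl gives a 10-fold higher number from compound 1 to compound 4 (1.01 log units; beyond the scatter) and so lower toxicity in this test. Both groups are six-membered aromatic rings of carbon only, with no hydrogen-bond donors or acceptors and no net charge, and they differ by little in size, at 7 heavy atoms against 8, so a small change in structure can have a large effect here. Nothing measured here explains the size of this step.

This single step changes both the number of methyl groups and where they sit, and the two effects cannot be told apart. On these data alone, how a plain phenyl group, or a phenyl ring carrying an amine or a carboxylic acid, would behave on this oxygen remains open.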